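Chloro for hydroxy on the benzylidene ring

A few compounds are considered here, and "the series" means these few. Any claim that something is new, unique, unknown or untested is made for them only; others in the source may bear on it.

Working notes on the series. The parent compound 1 `CC1=CC[C@H](C(C)(C)NC(=S)NN)CC1` gives 200 nM in a functional assay on U-251 cells (Homo sapiens) for inhibition, read by sulforhodamine B assay, with a stated time of 48 h; a higher number here means a weaker inhibitor of growth, a lower number a stronger inhibitor of growth. The benzylidene compound 2 `CC1=CC[C@H](C(C)(C)NC(=S)N/N=C/c2ccccc2)CC1` gives 26300 nM in this assay. Compound 3 `CC1=CC[C@H](C(C)(C)NC(=S)N/N=C/c2ccc(O)cc2)CC1` is reported only as a limit, > 100000 nM in this assay. Going by the values given here, compound 3 thus sits at the limit of > 100000 nM in this assay, at which 1 of the 3 values shown sits, and the single measured change on the aromatic ring, an at least 3.8-fold higher number from compound 2 to compound 3 (0.58 log units; beyond the scatter), is a move to weaker growth inhibition.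

Compound 4 `CC1=CC[C@H](C(C)(C)NC(=S)N/N=C/c2ccc(Cl)cc2)CC1` differs from compound 3 by chloro in place of hydroxy on an aromatic carbon. Among the compounds with values here, the only measured step that bears on this change is the hydroxy-for-hydrogen step, an at least 3.8-fold higher number from compound 2 to compound 3 (0.58 log units; beyond the scatter), and it bears on it in reverse: the present change removes the hydroxy, while the entry of chloro has no measured counterpart among the three compounds. Reversing that step points back toward the number of compound 2, with the chloro contribution unknown. For compound 4 the step of an at least 3.3-fold lower number from compound 3 to compound 4 (0.52 log units; beyond the scatter) is therefore expected to run toward a lower number, beyond the scatter, bringing the value back below the limit. Compound 4 is estimated at 30000 nM in this assay, with a range from 8000 nM to 100000 nM.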

Compound 4, concentration for 50% growth inhibition: 69500 nM
Compound 4: middle estimate off by 2.3-fold (0.36 log units), on the low side, within the range that was stated.
By their numbers in this assay, from the lowest: compound 1; then compound 2; then compound 4. At a limit, above all of these: compound 3.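

Chloro on an aromatic carbon, para to a large group, gives a number rather than a limit in this assay, yet against hydrogen it is a move to weaker growth inhibition, a 2.6-fold higher number from compound 2 to compound 4 (0.42 log units; beyond the scatter), so neither of the two substituents shown at this position improves on the unsubstituted ring of compound 2. Against hydroxy, the change can be read only as a floor, an at least 1.4-fold lower number from compound 3 to compound 4 (0.15 log units; that floor lies within the scatter), and that floor does not establish an order between the two compounds. Compound 3 stands at a limit and not at a number: the limit of > 100000 nM in this assay, at which 1 of the 4 values shown sits.

As far as these compounds go, two substituents at one position of the ring give no trend, and it stays open whether an amine, a methoxy group or a carboxylic acid in the same place would match or improve on compound 2. From the compounds shown here alone, it also stays open whether any benzylidene compound can approach compound 1 at 200 nM, and whether chloro moved elsewhere on the ring would give a different number in this assay.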